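Swapping the aryl group on a weak adenosine antagonist

A few compounds are considered here, and "the series" means these few. Any claim that something is new, unique, unknown or untested is made for them only; others in the source may bear on it.

The account starts from compound 1 `COc1ccc(-c2nc3c(NC4CCCC4)ncnc3n2C)cc1`, tested in a functional assay on CHO cells for antagonist activity at adenosine receptor A2b (Homo sapiens), read by 33P incorporation, with a stated time of 20 min; on this read-out lower numbers stand for stronger inhibition and higher numbers for weaker inhibition. In this assay compound 1 gives only a limit of the assay, > 30000 nM, and no number. On the numbers shown, compound 1 stands at the limit of > 30000 nM in this assay, at which 1 of the 2 values shown sits. Going by the values given here, the other measured compound, compound 2 `CCCn1c(-c2ccccc2)nc2c(NC3CCC3)ncnc21`, differs from compound 1 in more than one place, and no single step connects the two; in this assay compound 2 gives 774 nM. The compound still to be measured is compound 3 `Cc1cccc(-c2nc3c(NC4CCCC4)ncnc3n2C)c1`. It keeps the core of compound 1 and changes one group: 3-methylphenyl in place of 4-methoxyphenyl on an aromatic carbon. Among the compounds with values here, compound 1 shows only a limit, and no measured step touches either compound 1 or compound 3, which leaves the size of this step unread from any measured pair. Compound 3 is expected to stay near compound 1, with at most a small gain, an at least 2.0-fold lower number from compound 1 to compound 3 (0.30 log units; that floor lies within the scatter). The estimate for compound 3 in this assay is 15000 nM, with a range from 3000 nM to 60000 nM, and a real chance that only a limit is again reported.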

Compound 3, inhibition constant: 6030 nM
The estimate for compound 3 lay 2.5-fold (0.40 log units) above the measured number, and the stated range covers the measured number.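

On this aromatic carbon of the five-membered ring, 3-methylphenyl in place of 4-methoxyphenyl gives an at least 4.9-fold lower number from compound 1 to compound 3 (0.69 log units; beyond the scatter) in this assay. Going by these compounds alone, with the core of compound 1 left unchanged, this single group is thus enough to bring the series from a limit to a measured number, something the earlier compounds, joined by no single step, could not show. The step can be read only as a minimum, since compound 1 gives a limit of the assay and not a number: the limit of > 30000 nM in this assay, at which 1 of the 3 values shown sits.

From the compounds shown here alone, the change moves the substituent on the phenyl ring and also replaces methoxy with methyl, so whether the improvement follows the new placing or the new group remains open; a 4-methylphenyl or a 3-methoxyphenyl group would separate the two. Within the data shown here, also open is how an amine or a carboxylic acid on this phenyl ring would read, and no step linking compound 2 to either of the other compounds can be read.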